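The source may report more compounds than this note shows. Statements on the series, on what has been measured and on what is new or still open speak of the compounds shown alone.

In a functional assay on A549 cells (Homo sapiens) for inhibition, read by MTT assay, with a stated time of 72 h (a higher number here means a weaker inhibitor, a lower number a stronger inhibitor), compound 2 `Nc1nc2cc(-c3nn(CCCCCC(=O)NO)c4ncnc(N)c34)ccc2o1` gives > 100000 nM as a limit of the assay, not a number. Compound 1 `Nc1nc2cc(-c3nn(CCCCCCCCCC(=O)NO)c4ncnc(N)c34)ccc2o1` gives > 50000 nM as a limit too. Compound 3 `Nc1nc2cc(-c3nn(CCCCCCC(=O)NO)c4ncnc(N)c34)ccc2o1` carries (hydroxycarbamoyl)methyl in place of the hydroxycarbamoyl of compound 2, on a saturated chain carbon, five bonds along the chain from an aromatic nitrogen ((hydroxycarbamoyl)methyl in place of hydroxycarbamoyl on a saturated chain carbon, five bonds along the chain from an aromatic nitrogen). The step that the two limits leave unreadable from compound 1 to compound 2 is the only measured one bearing on this change, and its size cannot be read. It therefore offers neither a size nor a direction to carry over, and no step beyond the scatter is expected in this assay for this change. The expected step is a number no higher from compound 2 to compound 3 (the limit leaves the size open) with no firm direction, and a further limit is the likeliest outcome. Compound 3 is expected near 100000 nM with an estimated range of 30000 nM to 200000 nM if a number is obtained.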

Compound 3, half-maximal inhibitory concentration: 33000 nM
Compound 3: the middle estimate sits 3.0-fold (0.48 log units) above what was measured; low and high end bracket the measured number.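

For the compounds shown here, compound 3 gives the first number in this set in this assay, so (hydroxycarbamoyl)methyl in place of hydroxycarbamoyl at this saturated chain carbon now has a readable lower bound: an at least 3.0-fold lower number from compound 2 to compound 3 (0.48 log units; beyond the scatter). The comparison with the longer chain of compound 1 is less firm, reading an at least 1.5-fold lower number from compound 1 to compound 3 (0.18 log units; that floor lies within the scatter). The result therefore shows a real difference for this change only against compound 2, and any claim about chain length rests on that single step.

On these data alone, compound 1 and compound 2 both stand as limits of the assay, so the full size of each step and any optimum in chain length remain open. As far as these compounds go, whether the hydroxycarbamoyl end is needed at all also remains open, and a carboxylic acid at the end of the chain of compound 3 would address that.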